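From methoxy to 2-oxopyrrolidin-1-yl on the shared core

This account rests on a few compounds, and the source may have more. Where it says the series, first, only, none or still open, it means among the compounds named here.

Compound 1 `O=C1C=CC2(C=C1)OCC(=O)N2S(=O)(=O)c1ccc(Cl)cc1` gives 860 nM
Compound 2 `COc1ccc(S(=O)(=O)N2C(=O)COC23C=CC(=O)C=C3)cc1` gives 1620 nM

Within the data shown here, in a functional assay on HepG2 cells (Homo sapiens) for inhibition, read by sulforhodamine B assay, with a stated time of 74 h (a higher number here means a weaker inhibitor, a lower number a stronger inhibitor), compound 2 at 1620 nM stands within the scatter of compound 1 at 860 nM and holds the upper of the only two numbers. Compound 3 `O=C1C=CC2(C=C1)OCC(=O)N2S(=O)(=O)c1ccc(N2CCCC2=O)cc1` carries 2-oxopyrrolidin-1-yl in place of methoxy on an aromatic carbon. Among the measured compounds shown here, the one measured step bearing on this site is a 1.9-fold higher number from compound 1 to compound 2 (0.28 log units; within the scatter), and no measurement yet covers the entering group. On that basis, the expected result is a 1.2-fold lower number from compound 2 to compound 3 (0.10 log units; within the scatter), which would be no step beyond the scatter. For compound 3 the estimated value is 1300 nM, with an expected range of 450 nM to 3800 nM.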

Compound 3, half-maximal inhibitory concentration: > 10000 nM
Compound 3: only a limit was reported; the forecaster's own chance of this, stated with the estimate: 3%; middle value at least 7.6-fold (0.88 log units) away from the limit.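

At this aromatic carbon, chloro and methoxy gave values within the scatter of each other, whereas 2-oxopyrrolidin-1-yl moves the number beyond it, with an at least 6.1-fold higher number from compound 2 to compound 3 (0.79 log units; beyond the scatter) and an at least 11-fold higher number from compound 1 to compound 3 (1.06 log units; beyond the scatter). So the site is not indifferent to every group placed on it. Compound 3 can be read only through a limit of the assay: the limit of > 10000 nM in this assay, at which 1 of the 3 values shown sits.

Going by these compounds, how far compound 3 lies past that limit stays open. So does whether the ring or the carbonyl of 2-oxopyrrolidin-1-yl carries the step, which pyrrolidin-1-yl, lacking the carbonyl, or an open-chain acetamido group could separate.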